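Chain extension from compound 3 to compound 4

A few compounds are considered here, and "the series" means these few. Any claim that something is new, unique, unknown or untested is made for them only; others in the source may bear on it.

Three measured compounds share a core and differ in one acyl group: compound 1 `CCCCCCCCNC(=O)[C@@H](NC(=O)c1nccc2ccccc12)[C@@H](C)O`, compound 2 `CCCCCCCCNC(=O)[C@@H](NC(=O)/C=C/c1ccccc1)[C@@H](C)O` and compound 3 `C/C=C/C=C/C(=O)N[C@H](C(=O)NCCCCCCCC)[C@@H](C)O`. In a functional assay on A-431 cells (Homo sapiens) for cytotoxicity, read by MTT assay, with a stated time of 48 h (on this read-out lower numbers stand for stronger inhibition and higher numbers for weaker inhibition), compound 1 gives 26900 nM, compound 2 gives 36000 nM and compound 3 gives 58200 nM, the highest of the three numbers, within the scatter of compound 2 and beyond it only against compound 1. Within the data shown here, the single one-point step, a 1.6-fold higher number from compound 2 to compound 3 (0.21 log units; within the scatter), concerns the acyl group and not the amide chain. Compound 4 `C/C=C/C=C/C(=O)N[C@H](C(=O)NCCCCCCCCCCCC)[C@@H](C)O` differs from compound 3 by butyl in place of hydrogen on a saturated chain carbon, eight bonds along the chain from an amide-type nitrogen. Among the measured compounds shown here, no measured step touches that chain, so no change beyond the scatter is expected. Compound 4 is estimated at 50000 nM, between 18000 nM and 140000 nM. The expected step is a 1.2-fold lower number from compound 3 to compound 4 (0.07 log units; within the scatter).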

Compound 4, half-maximal inhibitory concentration: 171000 nM
Compound 4: the middle estimate sits 3.4-fold (0.53 log units) below what was measured; the measured number lies above the stated range.
By their numbers in this assay, from the lowest: compounds 1, 2 and 3 (each within the scatter of the next, the first and the last beyond it); then compound 4.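

The amide chain is not a silent position: butyl in place of hydrogen on a saturated chain carbon, eight bonds along the chain from an amide-type nitrogen, gives a 2.9-fold higher number from compound 3 to compound 4 (0.47 log units; beyond the scatter) in this assay, a modest step beyond the scatter. Among these compounds, the only earlier step concerned the acyl group, so this is the first sign that the chain itself matters, with the longer chain of this pair giving the weaker inhibition. No evidence at hand accounts for this step.

Open, on these data alone, is whether a still longer chain continues this direction, and whether an amine or a carboxylic acid in place of butyl does the same. Also open, as far as these compounds go, is whether butyl gives a similar step with the acyl groups of compound 1 and compound 2.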